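Benzofuranyl for iodo on a nucleoside core

A few compounds are considered here, and "the series" means these few. Any claim that something is new, unique, unknown or untested is made for them only; others in the source may bear on it.

Compounds measured so far:
- compound 1, `Cc1ncnc2c1c(-c1cc3ccccc3o1)cn2[C@@H]1O[C@H](CO)[C@@H](O)[C@H]1O`: > 20000 nM
- compound 2, `COc1ncnc2c1c(I)cn2[C@@H]1O[C@H](CO)[C@@H](O)[C@H]1O`: 14800 nM

For the measured compounds named here, in a functional assay on K562 cells (Homo sapiens), read by MTT assay, with a stated time of 72 h (on this read-out lower numbers stand for stronger inhibition and higher numbers for weaker inhibition), compound 2 gives 14800 nM, the only plain number in the set. For compound 1 the result in this assay is a limit of the assay, > 20000 nM, and not a number, as the limit of > 20000 nM in this assay, at which 1 of the 2 values shown sits, records. Compound 3, `COc1ncnc2c1c(-c1cc3ccccc3o1)cn2[C@@H]1O[C@H](CO)[C@@H](O)[C@H]1O`, differs from compound 2 in one place: 1-benzofuran-2-yl in place of iodo on an aromatic carbon. Going by the values given here, no measured pair shows this same change, so the size of the step from compound 2 to compound 3 is not known from the data. Compound 1, which also carries 1-benzofuran-2-yl at that position, sits at > 20000 nM, which points to weak inhibition in this region of structures. For compound 3 in this assay, compound 3 is therefore expected to give about 18000 nM, within 4000 nM to 80000 nM, a step of a 1.2-fold higher number from compound 2 to compound 3 (0.09 log units; within the scatter), with a fair chance that only a limit is reported.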

Compound 3, half-maximal inhibitory concentration: 13100 nM
For compound 3 the middle estimate is 1.4-fold (0.14 log units) above the measured one; the measured number falls inside the stated range.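

In this assay, the exchange of iodo for 1-benzofuran-2-yl on this aromatic carbon gives a 1.1-fold lower number from compound 2 to compound 3 (0.05 log units; within the scatter), so the result does not separate a single iodine atom from a group of 9 heavy atoms with two aromatic rings. With 1-benzofuran-2-yl held in place, methoxy in place of methyl on an aromatic carbon gives an at least 1.5-fold lower number from compound 1 to compound 3 (0.18 log units; that floor lies within the scatter), which is a floor and not a measured size. That floor rests on compound 1, whose entry is a limit of the assay: the limit of > 20000 nM in this assay, at which 1 of the 3 values shown sits.

Still open, as far as these compounds go, is whether an amine or a carboxylic acid on this aromatic carbon would move the number beyond the scatter. Also open, from the compounds shown here alone, is whether a longer chain in place of the methoxy would change the result.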